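The compounds below may be only part of what the source reports. "The series", "measured", "known", "first", "only" and "open" are said of these compounds alone.

Compound 1 `CN(CCCn1ccnc1)C(=O)[C@@H]1CCCN1c1nccc(Nc2ccccc2)n1` gives 0% in an assay on isolated protein for inhibition of calcium/calmodulin-dependent protein kinase type II subunit alpha (Homo sapiens), read by HTRF, tested at 10 uM; on this read-out higher numbers stand for more inhibition at the one concentration tested (going by the name of the read-out) and lower numbers for less inhibition; compound 2 `COC(=O)C(CO)NC(=O)[C@@H]1CCCN1c1nccc(Oc2cccc(C)c2)n1` gives 0%; compound 3 `COC[C@@H]1CCCN1C(=O)[C@@H]1CCCN1c1nccc(Nc2ccccc2)n1` gives 0%.

On these numbers compound 3 stands level with compounds 1 and 2; none of the three reads beyond the scatter of this assay. Going by the values given here, only one measured step bears on the new compound: no change at the digits printed from compound 1 to compound 3 (within the scatter), which swapped the group on the carbonyl carbon and left the read-out unchanged within the scatter. Compound 4 `CN(C)CC(C)(C)CNC(=O)[C@@H]1CCCN1c1nccc(Nc2ccccc2)n1` carries a further change at the same place: (2-((dimethylamino)methyl)-2-methylpropyl)amino in place of 2-(methoxymethyl)pyrrolidin-1-yl on a carbonyl carbon. Because no change at the digits printed from compound 1 to compound 3 (within the scatter) showed no movement, the step of no change at the digits printed from compound 3 to compound 4 (within the scatter) is expected to be none beyond the scatter. Compound 4 is therefore estimated at 0%, with a range from -10% to 10%.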

Compound 4, a percentage reported as inhibition, at one concentration (the size of the read-out at that concentration, not a potency): 0%
Compound 4: the middle estimate sits on the measured number at the digits printed, and the stated range covers the measured number.
By their numbers in this assay, from the lowest: compounds 1, 2, 3 and 4 (each within the scatter of the next).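

In this assay, putting an open chain on the carbonyl carbon gives no change at the digits printed from compound 3 to compound 4 (within the scatter), and the comparison with the imidazole-bearing group gives no change at the digits printed from compound 1 to compound 4 (within the scatter). A group with no ring, with a hydrogen-bond donor that 2-(methoxymethyl)pyrrolidin-1-yl lacks and without its defined stereocentre, therefore leaves this read-out level as well. No supporting data are available to explain this flat reading.

As far as these compounds go, it remains open whether any group on this carbonyl carbon can lift the read-out at all. A carboxylic acid or a longer chain ending in a primary amine would probe that question.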